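The source may report more compounds than this note shows. Statements on the series, on what has been measured and on what is new or still open speak of the compounds shown alone.

Compound 1 `CCCCCCCCCCCC[C@@H](O)[C@H]1CC[C@H]([C@H](O)CCCCCCCCCCN(C)C(=O)c2ccnn2C)O1`: 4170 nM
Compound 2 `CCCCCCCCCCCC[C@@H](O)[C@H]1CC[C@H]([C@H](O)CCCCCCCCCCNCc2ccnn2C)O1`: 1410 nM

Both values come from a functional assay on KM12 cells (Homo sapiens) for inhibition, read by sulforhodamine B assay, with a stated time of 48 h; a higher number here means a weaker inhibitor of growth, a lower number a stronger inhibitor of growth. Compound 2 has the lower number of the pair, 1410 nM, which makes it the stronger inhibitor of growth measured so far.

The next compound, compound 3 `CCCCCCCCCCCC[C@@H](O)[C@H]1CC[C@H]([C@H](O)CCCCCCCCCCC(=O)Nc2ccnn2C)O1`, keeps the shared core and alters only the end of the long chain: (1-methyl-1H-pyrazol-5-yl)carbamoyl in place of ((1-methyl-1H-pyrazol-5-yl)methyl)amino on a saturated chain carbon, ten or more bonds along the chain from an oxygen on a saturated carbon and a saturated ring carbon.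

Within the data shown here, only one measured step bears on this, and only in part: a 3.0-fold lower number from compound 1 to compound 2 (0.47 log units; beyond the scatter), a modest change. That step removed a carbonyl from the group on the chain, whereas this one brings a carbonyl back, although the carbamoyl group of compound 3 is not the group found in compound 1. A step of similar size in the opposite direction, toward a higher number and weaker inhibition, therefore seems likely. The estimated step is a 2.1-fold higher number from compound 2 to compound 3 (0.33 log units; beyond the scatter). Compound 3 is expected at about 3000 nM, with an estimated range from 1000 nM to 9000 nM.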

Compound 3, concentration for 50% growth inhibition: 100000 nM
Beside the measured number, compound 3's estimate is 33-fold (1.52 log units) below it; the whole stated range lies below it.
By their numbers in this assay, from the lowest: compound 2; then compound 1; then compound 3.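

The end of the long chain is far more sensitive in this assay than the first pair suggested: a 71-fold higher number from compound 2 to compound 3 (1.85 log units; beyond the scatter), a large step where the earlier change was modest. Carrying a carbonyl does not by itself fix the number, since compound 1 and compound 3 both have one in this group, yet a 24-fold higher number from compound 1 to compound 3 (1.38 log units; beyond the scatter); what separates them is how the carbonyl and nitrogen are arranged along the link and whether that nitrogen bears a methyl. Nothing given here accounts for the size of either step.

Compound 1 and compound 3 differ in both the arrangement and the methyl, so the compounds shown cannot say which of the two matters more; a methyl(1-methyl-1H-pyrazol-5-yl)carbamoyl group at the same place on the chain would pull these apart. On these data alone, it also remains open how much of the growth inhibition of compound 2 depends on the (1-methyl-1H-pyrazol-5-yl)methyl part of its group, which a plain primary amine at the chain end would test.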